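Working notes on a small series and one pending compound

The source may report more compounds than this note shows. Statements on the series, on what has been measured and on what is new or still open speak of the compounds shown alone.

Measured in a functional assay for antagonist activity at Neuropeptides B/W receptor type 1 (Homo sapiens), read by cAMP accumulation; on this read-out lower numbers stand for stronger inhibition and higher numbers for weaker inhibition:
compound 1 `O=[N+]([O-])c1ccc2[nH]c(-c3ccc(C(F)(F)F)cc3)nc2c1`: > 31600 nM
compound 2 `O=[N+]([O-])c1ccc2[nH]c(-c3cccc(Cl)c3)nc2c1`: 9980 nM
compound 3 `Cc1cc(-c2nc3cc([N+](=O)[O-])ccc3[nH]2)ccc1Cl`: 2290 nM

Compound 1 sits at the limit of > 31600 nM in this assay, at which 1 of the 3 values shown sits, so its entry is a limit of the assay and not a number. Compound 2 and compound 3 give actual numbers in this assay, and of the three entries the one for compound 3 is the lowest; no step between any two of these compounds is worked out here, so only the values themselves are recorded.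

Compound 4 `O=[N+]([O-])c1ccc2[nH]c(-c3ccc(N4CCCC4)cc3)nc2c1` has not yet been measured. It differs from compound 1 by pyrrolidin-1-yl in place of trifluoromethyl on an aromatic carbon, para to a large group. Among the compounds with values here, as no step between measured compounds is available, the direction for this change is open; a step of an at least 3.9-fold lower number from compound 1 to compound 4 (0.59 log units; beyond the scatter) toward stronger inhibition is expected, with the reservation that it starts from a limit and could equally stay within the scatter or end at the limit again. For compound 4 the estimate in this assay is 8000 nM, expected to lie between 1500 nM and 40000 nM.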

Compound 4, half-maximal inhibitory concentration: 1810 nM
Estimate against measurement, compound 4: 4.4-fold (0.65 log units) above; the range from low to high includes it.
By their numbers in this assay, from the lowest: compounds 4 and 3 (each within the scatter of the next); then compound 2. At a limit, above all of these: compound 1.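

In this assay, within the data shown here, pyrrolidin-1-yl in place of trifluoromethyl on this aromatic carbon, para to a large group, gives an at least 17-fold lower number from compound 1 to compound 4 (1.24 log units; beyond the scatter), the one step that can be read so far. The position is therefore not closed to inhibition, since with pyrrolidin-1-yl there compound 4 gives a real number of 1810 nM. Compound 1 stands at a limit of the assay, so the step marks a minimum and not a measured size: the limit of > 31600 nM in this assay, at which 1 of the 4 values shown sits.

A single pair cannot separate what pyrrolidin-1-yl contributes through its ring from what it contributes through its nitrogen, and a dimethylamino group, a piperidin-1-yl group or a morpholin-4-yl group on the same carbon would be needed to tell these apart. Compound 2 and compound 3 each differ from compound 4 in more than one place and give no reading on that question.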